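Swapping Nitro for Methoxy on the Aromatic Ring

The source may report more compounds than this note shows. Statements on the series, on what has been measured and on what is new or still open speak of the compounds shown alone.

Measured so far in a functional assay on NCI-H460 cells (Homo sapiens) for cytotoxicity, read by sulforhodamine B assay, with a stated time of 3 days; a lower number here means a stronger inhibitor, a higher number a weaker inhibitor:
Compound 1 `Cc1ccc(Cn2cc(CO)c3ccccc32)cc1`: 31 nM
Compound 2 `O=[N+]([O-])c1ccc(Cn2cc(CO)c3ccccc32)cc1`: 79 nM

Of the two measured compounds, compound 2 stands at the higher number in this assay, at 79 nM, and is therefore the weaker inhibitor of the pair. The next compound to be tested is compound 3 `COc1ccc(Cn2cc(CO)c3ccccc32)cc1`, and the change from compound 2 is methoxy in place of nitro on an aromatic carbon. Methoxy takes the place of nitro on an aromatic carbon of a six-membered aromatic ring of carbon only, para to a large group.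

Among the measured compounds shown here, only one measured step bears on this change: a 2.5-fold higher number from compound 1 to compound 2 (0.41 log units; beyond the scatter). That step is modest and has nitro as its incoming group, with methyl leaving. For the measured compounds named here, no measured compound carries methoxy, so the data offer no direct reading for it. On the assumption that methoxy tracks methyl more closely than nitro here, a modest move back towards a lower number is expected, no larger than the measured step from methyl to nitro. The expected change is a 2.1-fold lower number from compound 2 to compound 3 (0.32 log units; beyond the scatter). For compound 3 the estimated value is 38 nM, with an expected range from 14 nM to 100 nM.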

Compound 3, half-maximal inhibitory concentration: 79 nM
Compound 3: middle estimate off by 2.1-fold (0.32 log units), on the low side, within the range that was stated.
By their numbers in this assay, from the lowest: compound 1; then compounds 2 and 3 (each within the scatter of the next).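

In this assay, the exchange at this position gives no change at the digits printed from compound 2 to compound 3 (within the scatter), so methoxy and nitro, on the aromatic carbon para to a large group, cannot be told apart here. Methyl now stands apart from two different groups rather than one: the new comparison gives a 2.5-fold higher number from compound 1 to compound 3 (0.41 log units; beyond the scatter), matching a 2.5-fold higher number from compound 1 to compound 2 (0.41 log units; beyond the scatter), and compound 1 is the strongest inhibitor of the three. No measurement at hand accounts for the match between methoxy and nitro or for the separation of methyl.

The compounds shown leave open whether the lower number belongs to methyl alone or extends to a longer chain such as ethyl, and whether chloro, an amine or a carboxylic acid at the same place would stand with compound 1 or with compounds 2 and 3. Among the compounds shown here, they also leave open whether the same grouping would hold with these groups at a different place on the ring, or on a core other than the one these three compounds share.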